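Metabolic stability of three lactam-substituted analogues and a fourth

This account rests on a few compounds, and the source may have more. Where it says the series, first, only, none or still open, it means among the compounds named here.

Measured compounds:
compound 1 `Cc1nc(N2CCC(N3CCNC3=O)CC2)nc2ccc(NC(=O)/C=C/c3ccc(OC(F)(F)F)cc3)cc12` — 89%
compound 2 `Cc1nc(N2CCC(N3C(=O)CCC3=O)CC2)nc2ccc(NC(=O)/C=C/c3ccc(OC(F)(F)F)cc3)cc12` — 40%
compound 3 `Cc1nc(N2CCC(N3CCCC3=O)CC2)nc2ccc(NC(=O)/C=C/c3ccc(OC(F)(F)F)cc3)cc12` — 85%

In an ADME assay on microsomes from liver (Mus musculus) for metabolic stability, with a stated time of 30 min (a higher number here means that more of the compound is left, a lower number that less of the compound is left), compound 3 gives 85%, the second highest of the three numbers; it sits close to compound 1, with a change a number 4 percentage points lower from compound 1 to compound 3 (within the scatter), and far from compound 2, with a change a number 45 percentage points higher from compound 2 to compound 3 (beyond the scatter). Compound 4 `Cc1nc(N2CCC(N3CCN(C)C3=O)CC2)nc2ccc(NC(=O)/C=C/c3ccc(OC(F)(F)F)cc3)cc12` carries 3-methyl-2-oxoimidazolidin-1-yl in place of 2-oxopyrrolidin-1-yl on a saturated ring carbon. Among the measured compounds shown here, two measured steps bear on this: the step of a number 4 percentage points lower from compound 1 to compound 3 (within the scatter) shows that exchanging one five-membered ring with one hetero atom for one with two hetero atoms left the number essentially unchanged, whereas the large drop a number 49 percentage points lower from compound 1 to compound 2 (beyond the scatter) came from a ring bearing two carbonyls, which compound 4 does not have. A step within the scatter is therefore expected, a number 3 percentage points lower from compound 3 to compound 4 (within the scatter). Compound 4 is estimated at 82%, with a range from 62% to 95%.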

Compound 4, percent of the compound remaining: 94%
Estimate against measurement, compound 4: 12 percentage points below; the range from low to high includes it.
By their numbers in this assay, from the lowest: compound 2; then compounds 3, 1 and 4 (each within the scatter of the next).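

In this assay, methyl in place of hydrogen on the amide-type nitrogen in the ring stays within the scatter (a number 5 percentage points higher from compound 1 to compound 4 (within the scatter)), and 3-methyl-2-oxoimidazolidin-1-yl likewise stays within the scatter of 2-oxopyrrolidin-1-yl (a number 9 percentage points higher from compound 3 to compound 4 (within the scatter)). The large gap to 2,5-dioxopyrrolidin-1-yl holds for this group too (a number 54 percentage points higher from compound 2 to compound 4 (beyond the scatter)), which leaves compound 2 alone apart from the other three at this position. Nothing measured here accounts for these results. The compounds shown leave open whether a longer chain such as ethyl on that nitrogen, or a carboxylic acid on a chain there, would give a number like that of compound 4.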